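Sulfonyl substituent swap: working notes on cytotoxicity

A few compounds are considered here, and "the series" means these few. Any claim that something is new, unique, unknown or untested is made for them only; others in the source may bear on it.

- compound 1 `CCCS(=O)(=O)N1CCC2(CC1)OOC1(CCCCC1)OO2`: > 100 ug/mL
- compound 2 `O=S(=O)(CCCCl)N1CCC2(CC1)OOC1(CCCCCC1)OO2`: > 100 ug/mL

Both compounds were tested in a functional assay on Huh-7 cells (Homo sapiens) for cytotoxicity, read by MTT assay, with a stated time of 72 h; on this read-out lower numbers stand for higher toxicity in this test and higher numbers for lower toxicity in this test. Compound 1 gives > 100 ug/mL, which is a limit and not a number. Compound 2 likewise gives only a limit, > 100 ug/mL. Among the measured compounds shown here, the measured series therefore offers only (the limit of > 100 ug/mL in this assay, at which 2 of the 2 values shown sit), and no step between measured compounds is available.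

The next compound is compound 3 `O=S(=O)(c1ccc(Br)cc1F)N1CCC2(CC1)OOC1(CCCCC1)OO2`, with 4-bromo-2-fluorophenyl in place of propyl on a sulfonyl sulfur.

With compound 1 at > 100 ug/mL, a small move toward lower numbers in this assay is expected, possibly none beyond the scatter. The expected size of the change is an at least 1.1-fold lower number from compound 1 to compound 3 (0.04 log units; that floor lies within the scatter). Compound 3 is expected at 90 ug/mL, with an estimated range of 30 ug/mL to 200 ug/mL.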

Compound 3, half-maximal cytotoxic concentration: > 100 ug/mL
Compound 3 was reported as a limit; the forecaster's own chance of this, stated with the estimate: 55%; middle value at least 1.1-fold (0.04 log units) from the limit.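

Compound 1 and compound 3 both stand only as limits in this assay, so no step can be read between them: the limit of > 100 ug/mL in this assay, at which 3 of the 3 values shown sit.

The compounds shown leave open at what concentration either becomes toxic to these cells, and whether 4-bromo-2-fluorophenyl in place of propyl on a sulfonyl sulfur shifts that concentration.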